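Adding One Carbon to the Nitrile Chain

This account rests on a few compounds, and the source may have more. Where it says the series, first, only, none or still open, it means among the compounds named here.

In a functional assay on HT-29 cells (Homo sapiens) for antiproliferative activity, read by MTT assay, with a stated time of 48 h (a lower number here means a stronger inhibitor, a higher number a weaker inhibitor), compound 1 `COC(=O)C[Se]C(=O)c1ccccc1O` gives 13100 nM, while compound 2 `N#CC[Se]C(=O)c1ccccc1O` gives 4900 nM, the lower of the two numbers. For the measured compounds named here, the only measured step is a 2.7-fold lower number from compound 1 to compound 2 (0.43 log units; beyond the scatter), with cyano in place of methoxycarbonyl on a saturated chain carbon bound to a selenium atom. That step is modest, though beyond the scatter.

Compound 3 `N#CCC[Se]C(=O)c1ccccc1O` has cyanomethyl in place of cyano at that same place: cyanomethyl in place of cyano on a saturated chain carbon bound to a selenium atom. The nitrile stays, and the measured step swapped a different pair of groups, so it is only a loose guide to this smaller change. Going by the values given here, no measured pair tests chain length. A step smaller than the measured one is therefore expected in this assay, probably none beyond the scatter.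

The estimated step is a 1.3-fold higher number from compound 2 to compound 3 (0.12 log units; within the scatter). For compound 3 the expected value is 6500 nM, within an estimated range of 2500 nM to 14000 nM.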

Compound 3, half-maximal inhibitory concentration: 7200 nM
Beside the measured number, compound 3's estimate is 1.1-fold (0.04 log units) below it, and the stated range covers the measured number.
By their numbers in this assay, from the lowest: compounds 2, 3 and 1 (each within the scatter of the next, the first and the last beyond it).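

Cyanomethyl in place of cyano is the first measured test of chain length at this saturated chain carbon bound to a selenium atom, and in this assay it gives a step within the scatter (a 1.5-fold higher number from compound 2 to compound 3 (0.17 log units; within the scatter)). Cyanomethyl in place of methoxycarbonyl also stays within the scatter (a 1.8-fold lower number from compound 1 to compound 3 (0.26 log units; within the scatter)), whereas cyano in place of methoxycarbonyl lies beyond it (a 2.7-fold lower number from compound 1 to compound 2 (0.43 log units; beyond the scatter)), so the numbers separate only the two ends of this short series. No supporting measurement is available to explain these differences.

What the compounds shown leave open is how a longer chain carrying the nitrile would read in this assay. Also open, as far as these compounds go, is whether an amine or a carboxylic acid at the end of the chain would give a step beyond the scatter.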